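The source may hold more compounds than are shown below. What is called first, only, known or untested is meant among the compounds shown, and "the series" means these compounds.

Compound 1 `O=C(Nc1ccc(Oc2ccnc3[nH]ccc23)cc1)c1nn(-c2ccccc2)ccc1=O`: 10500 nM
Compound 2 `O=C(Nc1ccc(Oc2ccnc3[nH]ccc23)cc1)c1nn(-c2ccc(Br)cc2F)ccc1=O`: 26100 nM

In a functional assay on A549 cells (Homo sapiens) for cytotoxicity, read by MTT assay, with a stated time of 72 h (a higher number here means a weaker inhibitor, a lower number a stronger inhibitor), compound 1 holds the lowest of the two numbers, with compound 2 lying above it. Compound 3 `O=C(Nc1ccc(Oc2ccnc3[nH]ccc23)cc1)c1nn(-c2ccc(Cl)c(C(F)(F)F)c2)ccc1=O` differs from compound 1 by 4-chloro-3-(trifluoromethyl)phenyl in place of phenyl on an aromatic nitrogen. Within the data shown here, the one measured step that bears on this change, a substituted phenyl replacing plain phenyl at the same place, is a 2.5-fold higher number from compound 1 to compound 2 (0.40 log units; beyond the scatter). A step of similar size and in the same direction is therefore expected for the new substituted phenyl, a 1.9-fold higher number from compound 1 to compound 3 (0.28 log units; within the scatter). Compound 3 is expected to give 20000 nM in this assay, with a likely range from 7000 nM to 60000 nM.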

Compound 3, half-maximal inhibitory concentration: 2190 nM
Compound 3: middle estimate off by 9.1-fold (0.96 log units), on the high side; measured number outside the range, below it.
By their numbers in this assay, from the lowest: compound 3; then compound 1; then compound 2.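

In this assay, adding groups to this phenyl does not move the number in one fixed direction: 4-chloro-3-(trifluoromethyl)phenyl gives a 4.8-fold lower number from compound 1 to compound 3 (0.68 log units; beyond the scatter), while the 4-bromo-2-fluorophenyl of compound 2 goes against this trend. Exchanging one substituted phenyl for the other gives a 12-fold lower number from compound 2 to compound 3 (1.08 log units; beyond the scatter), so at this position the identity and placement of the substituents matter, not merely their presence. No measurement here explains this difference.

The compounds shown leave open whether the chlorine or the trifluoromethyl alone accounts for the lower number. They also leave open how a phenyl bearing an amine or a carboxylic acid would behave here.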